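The compounds below may be only part of what the source reports. "The series", "measured", "known", "first", "only" and "open" are said of these compounds alone.

Compound 1 `Cc1ccc(C#Cc2ccc(CCC(=O)O)cc2)cc1` gives 107 nM in an in vitro functional assay on 1321-N1 cells for agonist activity at Free fatty acid receptor 1 (Homo sapiens), read by fluorescence; a higher number here means that more compound is needed for the effect, a lower number that less compound is needed.
Compound 2 `C#Cc1cccc(C#Cc2ccc(CCC(=O)O)cc2)c1` gives 155 nM in this assay.
Compound 3 `Cc1cccc(C#Cc2ccc(OCC(=O)O)cc2)c1` gives 513 nM in this assay.

Among these three, compound 2 holds the second highest number. Its number and that of compound 1 lie within the scatter of each other, so nothing separates them; compound 3 gives a higher number than compound 2, a gap beyond the scatter. Compound 4 `N#Cc1cccc(C#Cc2ccc(CCC(=O)O)cc2)c1` has not yet been measured in this assay. Compared with compound 2, it carries cyano in place of ethynyl on an aromatic carbon. Going by the values given here, no measured pair shows a change of this kind, so the size of the step is not known from the data. The expected change from compound 2 to compound 4 is a 1.3-fold higher number from compound 2 to compound 4 (0.11 log units; within the scatter), likely within the scatter. For compound 4, the expected value in this assay is 200 nM, in the range from 80 nM to 500 nM.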

Compound 4, half-maximal effective concentration: 91.2 nM
Compound 4: middle estimate off by 2.2-fold (0.34 log units), on the high side; low and high end bracket the measured number.
By their numbers in this assay, from the lowest: compounds 4, 1 and 2 (each within the scatter of the next); then compound 3.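

In this assay, cyano in place of ethynyl on an aromatic carbon, meta to a large group, gives a 1.7-fold lower number from compound 2 to compound 4 (0.23 log units; within the scatter), so nothing separates the two groups at this position, although cyano brings a hydrogen-bond acceptor that ethynyl lacks. No evidence on hand bears on this result. The compounds shown leave open how an amine, a methoxy group or a chlorine atom on this same carbon would read in this assay, and whether cyano and ethynyl also stay within the scatter on the core of compound 3.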